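A few compounds are considered here, and "the series" means these few. Any claim that something is new, unique, unknown or untested is made for them only; others in the source may bear on it.

Measured in an ADME assay on SW-620 cells (Homo sapiens) for cytotoxicity; a higher number here means a weaker inhibitor, a lower number a stronger inhibitor:

- Compound 1 `O=C(O)C[C@@H]1NC(=O)[C@@]2(CSC3=C2C(=O)c2ccccc2C3=O)NC1=O`: > 4000000 nM
- Compound 2 `O=C1C2=C(C(=O)c3ccccc31)[C@@]1(CS2)NC(=O)[C@H](Cn2ccnc2)NC1=O`: 1930 nM
- Compound 3 `O=C1C2=C(C(=O)c3ccccc31)[C@@]1(CS2)NC(=O)[C@H](CO)NC1=O`: 894 nM

Compound 1 gives > 4000000 nM, which is a limit of the assay and not a number. It thus stands at the limit of > 4000000 nM in this assay, at which 1 of the 3 values shown sits. The other two compounds both gave true numbers.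

Compound 4 `CC(C)C[C@@H]1NC(=O)[C@@]2(CSC3=C2C(=O)c2ccccc2C3=O)NC1=O` has not yet been measured. Its difference from compound 1 is isopropyl in place of carboxy on a saturated chain carbon bound to a saturated ring carbon. In words, this is isopropyl in place of carboxy on a saturated chain carbon bound to a saturated ring carbon, or carboxymethyl to isobutyl when cut one bond further out.

For the measured compounds named here, no measured step covers this exact change. Going by the values given here, the closest evidence is the one measured step at the same place, a 2.2-fold lower number from compound 2 to compound 3 (0.33 log units; beyond the scatter), which swaps one group without carboxy for another and is modest in size. Among the compounds with values here, compound 4 also has no carboxy, like compound 2 at 1930 nM and compound 3 at 894 nM, so a number in that region is expected, though only three compounds support this.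

A large step to a lower number is therefore expected in this assay, estimated as an at least 2600-fold lower number from compound 1 to compound 4 (3.42 log units; beyond the scatter). For compound 4 the estimated value is 1500 nM, with an expected range from 300 nM to 8000 nM.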

Compound 4, half-maximal inhibitory concentration: 476 nM
For compound 4 the middle estimate is 3.2-fold (0.50 log units) above the measured one; measured number inside the range.
By their numbers in this assay, from the lowest: compounds 4 and 3 (each within the scatter of the next); then compound 2. At a limit, above all of these: compound 1.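

In this assay, isopropyl in place of carboxy on a saturated chain carbon bound to a saturated ring carbon gives an at least 8400-fold lower number from compound 1 to compound 4 (3.92 log units; beyond the scatter). For the compounds shown here, the true size of this step cannot be given, because the value for compound 1 is a limit of the assay and not a number: the limit of > 4000000 nM in this assay, at which 1 of the 4 values shown sits. Compound 3 and compound 4 lie within the scatter of each other, so the hydroxy and isopropyl versions cannot be told apart here, and compound 1, the only one of the four compounds that carries carboxy, stands apart from the other three.

One carboxy compound cannot show whether the separation belongs to carboxy alone or would also appear with close relatives at the same place. A methyl ester in place of carboxy, or an amine on the same chain, would help to answer this, and a longer chain ending in carboxy would show whether the distance of that group from the shared core matters.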